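A few compounds are considered here, and "the series" means these few. Any claim that something is new, unique, unknown or untested is made for them only; others in the source may bear on it.

Measured so far in a functional assay on K562 cells (Homo sapiens) for antiproliferative activity, read by MTT assay; on this read-out higher numbers stand for weaker inhibition and lower numbers for stronger inhibition:
- compound 1 `O=C(CCCCCNC(=S)NN=C(c1ccccc1)c1ccccc1)NO` gives 3810 nM
- compound 2 `C/C(=N\NC(=S)NCCCCCC(=O)NO)c1ccc(F)cc1` gives 1890 nM
- compound 3 `C/C(=N\NC(=S)NCCCCCC(=O)NO)c1cccc(C(F)(F)F)c1` gives 1400 nM

Compound 1 stands level with compound 2, within the scatter, and its number is higher than that of compound 3 by a gap beyond the scatter. The unmeasured compound 4 `O=C(CCCCCNC(=S)N/N=C(\c1ccccc1)c1cccc([N+](=O)[O-])c1)NO` keeps the core of compound 1 and has nitro in place of hydrogen on an aromatic carbon, meta to a large group (nitro in place of hydrogen on an aromatic carbon). For the measured compounds named here, no measured pair differs in one place only, so this change has no direct precedent. Compound 2 and compound 3 each carry a substituted ring, but both also differ from compound 1 elsewhere. Only compound 3, at 1400 nM, sits clearly lower than compound 1, which is weak support for a small move towards a lower number in this assay. No step beyond the scatter is the likeliest outcome. The expected change is a 1.4-fold lower number from compound 1 to compound 4 (0.13 log units; within the scatter), an estimated step within the scatter. For compound 4 the estimated value is 2800 nM, with an expected range from 1200 nM to 6500 nM.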

Compound 4, half-maximal inhibitory concentration: 1630 nM
The estimate for compound 4 lay 1.7-fold (0.23 log units) above the measured number; the measured number falls inside the stated range.
By their numbers in this assay, from the lowest: compounds 3, 4, 2 and 1 (each within the scatter of the next, the first and the last beyond it).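

In this assay, for the compounds shown here, nitro in place of hydrogen on an aromatic carbon, meta to a large group, gives a 2.3-fold lower number from compound 1 to compound 4 (0.37 log units; beyond the scatter) and is the only single-place change that can be read, so this position now has a direct measurement rather than only indirect comparisons. The shared core accepts the added nitro at this place without a move towards a higher number, and the step lies beyond the usual scatter, although it is modest and rests on one pair. No supporting data accompany the step, so the reason for the lower number remains unexplained.

The compounds shown leave open whether this step is specific to nitro or would also appear with another group at the same place, such as an amine, a nitrile or a carboxylic acid. They also leave open whether nitro would have a similar effect elsewhere on the aromatic ring, on the second aromatic ring of compound 1, or alongside a longer chain leading to the hydroxamic acid.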